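Swapping a Chloromethyl Ring for a Hydroxymethyl Oxazole

A few compounds are considered here, and "the series" means these few. Any claim that something is new, unique, unknown or untested is made for them only; others in the source may bear on it.

Of the compounds shown here, three have been measured in an assay with Cystic fibrosis transmembrane conductance regulator (Rattus norvegicus) as the target; on this read-out higher numbers stand for weaker binding and lower numbers for tighter binding. Compound 1 `COc1ccc(COc2ccccc2-c2cc(CO)on2)cc1` gives 64000 nM in this assay. Compound 2 `COc1ccc(COc2ccccc2C2=NOC(CCl)C2)cc1` gives 59000 nM, and compound 3 `COc1cccc(COc2ccccc2C2=NOC(CCl)C2)c1` gives 66000 nM; all three numbers lie within the usual scatter of one another, so no order among them can be read. The change from compound 2 to compound 1 is a group of 7 heavy atoms (4 carbon, 1 nitrogen, 2 oxygen; one five-membered aromatic ring with 2 hetero atoms) in place of a group of 7 heavy atoms (4 carbon, 1 nitrogen, 1 oxygen, 1 chlorine; one five-membered non-aromatic ring with 2 hetero atoms), on an aromatic carbon, and it produced a 1.1-fold higher number from compound 2 to compound 1 (0.04 log units; within the scatter).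

Compound 4 `COc1cccc(COc2ccccc2-c2cc(CO)on2)c1` has not yet been measured. It differs from compound 3 by a group of 7 heavy atoms (4 carbon, 1 nitrogen, 2 oxygen; one five-membered aromatic ring with 2 hetero atoms) in place of a group of 7 heavy atoms (4 carbon, 1 nitrogen, 1 oxygen, 1 chlorine; one five-membered non-aromatic ring with 2 hetero atoms), on an aromatic carbon, the same change that turns compound 2 into compound 1, made at a place described in the same words. The cores of compound 3 and compound 2 are made of the same atoms joined differently; that difference between the two cores is not broken down here.

Because the earlier step of a 1.1-fold higher number from compound 2 to compound 1 (0.04 log units; within the scatter) stayed within the scatter, compound 4 is expected to show a step of a 1.1-fold higher number from compound 3 to compound 4 (0.03 log units; within the scatter) in this assay. Compound 4 is therefore estimated at 71000 nM, with a likely range from 40000 nM to 125000 nM.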

Compound 4, dissociation constant: 72000 nM
For compound 4 the middle estimate is 1.0-fold (0.01 log units) below the measured one, and the stated range covers the measured number.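

In this assay, putting 5-(hydroxymethyl)-1,2-oxazol-3-yl in place of the five-membered non-aromatic ring group gives a 1.1-fold higher number from compound 3 to compound 4 (0.04 log units; within the scatter), so this step, like the earlier one, stays within the scatter. Set beside the earlier step, the change carries over between the two cores with no readable difference: the same change on two cores in this assay, a 1.1-fold higher number (0.04 log units; within the scatter) from compound 2 to compound 1 and a 1.1-fold higher number (0.04 log units; within the scatter) from compound 3 to compound 4, 1.0-fold (0.00 log units) apart, within the scatter of two such steps. This shows that the swap left the number unmoved on both cores, but a change with no readable effect cannot show that the two cores would respond alike to a change that does move the number, and it says nothing about any other core.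

The compounds shown leave open whether any group at this place on the aromatic ring can move the number beyond the scatter. An amine, a carboxylic acid or a longer chain in place of the hydroxymethyl group on the oxazole would be one way to test this, and all four compounds here give no answer to it.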